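The source may report more compounds than this note shows. Statements on the series, on what has been measured and on what is new or still open speak of the compounds shown alone.

Measured in a functional assay on A549 cells (Homo sapiens) for inhibition, read by CCK-8 assay, with a stated time of 72 h, tested at 10 uM; a lower number here means a weaker effect, a higher number a stronger effect of the compound at the concentration tested:
Compound 1, `CN(C)C(=O)c1cc2cnc(Nc3ccc(S(=O)(=O)NCCCN=C=S)cc3)nc2n1C1CCCC1`: 102%
Compound 2, `CN(C)C(=O)c1cc2cnc(Nc3ccc(S(=O)(=O)NCCCCCCN=C=S)cc3)nc2n1C1CCCC1`: 101%
Compound 3, `CN(C)C(=O)c1cc2cnc(Nc3ccc(C(=O)NCCCN=C=S)cc3)nc2n1C1CCCC1`: 103%

Compound 3 stands within the scatter of the other two: the step of a number 1 percentage points higher from compound 1 to compound 3 (within the scatter) is small, and the values of compound 2 and compound 3 likewise lie close together. All three compounds show near-complete inhibition at the concentration tested.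

Compound 4, `CN(C)C(=O)c1cc2cnc(Nc3ccc(C(=O)NCCCCCCN=C=S)cc3)nc2n1C1CCCC1`, has not yet been measured. It differs from compound 3 by a group of 6 heavy atoms (4 carbon, 1 nitrogen, 1 sulfur; no ring) in place of a group of 3 heavy atoms (1 carbon, 1 nitrogen, 1 sulfur; no ring), on a saturated chain carbon, three bonds along the chain from an amide-type nitrogen.

Going by the values given here, the one measured step that bears on this change is the corresponding lengthening on the sulfonamide analogue, a number 1 percentage points lower from compound 1 to compound 2 (within the scatter), which stayed within the scatter. On the amide series the same chain extension is therefore expected to leave the read-out essentially unchanged, with a step of a number 1 percentage points lower from compound 3 to compound 4 (within the scatter) in this assay, in no particular direction beyond the scatter. For compound 4 the expected value in this assay is 102%, estimated to fall between 96% and 106%.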

Compound 4, a percentage reported as inhibition, at one concentration (the size of the read-out at that concentration, not a potency): 100%
For compound 4 the middle estimate is 2 percentage points above the measured one; the range from low to high includes it.
By their numbers in this assay, from the lowest: compounds 4, 2, 1 and 3 (each within the scatter of the next).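

In this assay, the lengthening on the amide series is a number 3 percentage points lower from compound 3 to compound 4 (within the scatter). The same chain change can now be read on two cores, and the two steps agree: the same change on two cores in this assay, a number 1 percentage points lower (within the scatter) from compound 1 to compound 2 and a number 3 percentage points lower (within the scatter) from compound 3 to compound 4, 2 percentage points apart, within the scatter of two such steps The wider exchange of the side group on the aromatic carbon is a number 2 percentage points lower from compound 1 to compound 4 (within the scatter), so neither this exchange nor the chain change separates the compounds in this read-out.

All four compounds show near-complete inhibition at a single concentration, so this read-out gives no potency and any difference in potency among them stays unresolved. On these data alone, whether a chain longer than that of compound 4, or an amine or a carboxylic acid in place of the group on the chain, would keep this effect remains open.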